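Halogen swap on the aryl ring: chloro to bromo

A few compounds are considered here, and "the series" means these few. Any claim that something is new, unique, unknown or untested is made for them only; others in the source may bear on it.

Of the compounds shown here, three have so far been measured in a functional assay on HCT-116 cells (Homo sapiens) for inhibition, read by sulforhodamine B assay, with a stated time of 72 h; a higher number here means a weaker inhibitor, a lower number a stronger inhibitor. Compound 3 `COc1ccc2cc(C(C)c3nnc4n3N=C(c3ccc(Cl)cc3)CS4)ccc2c1` gives 8800 nM, and compound 1 `COc1ccc2cc(C(C)c3nnc4n3N=C(c3ccc(Br)cc3)CS4)ccc2c1` gives 11700 nM. Compound 2 `CC(c1ccc(-c2ccccc2)c(F)c1)c1nnc2n1N=C(c1ccc(Cl)cc1)CS2` gives 7800 nM; the difference between the core of compound 2 and the core of compound 3 is not broken down here. Compound 1 differs from compound 3 by bromo in place of chloro on an aromatic carbon, and this gave a 1.3-fold higher number from compound 3 to compound 1 (0.12 log units; within the scatter). Compound 4 `CC(c1ccc(-c2ccccc2)c(F)c1)c1nnc2n1N=C(c1ccc(Br)cc1)CS2` has not yet been measured; it differs from compound 2 by bromo in place of chloro on an aromatic carbon, which is the same change at the same place as that from compound 3 to compound 1. The expected step is a 1.3-fold higher number from compound 2 to compound 4 (0.11 log units; within the scatter), set beside the measured one. This expectation rests on a single pair: because a 1.3-fold higher number from compound 3 to compound 1 (0.12 log units; within the scatter), the number for compound 4 is expected to sit close to that of compound 2, perhaps a little higher. Accordingly compound 4 is estimated at 10000 nM in this assay, with a likely range from 5000 nM to 20000 nM.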

Compound 4, half-maximal inhibitory concentration: 7100 nM
Beside the measured number, compound 4's estimate is 1.4-fold (0.15 log units) above it; low and high end bracket the measured number.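

In this assay, the change from 4-chlorophenyl to 4-bromophenyl gives a 1.1-fold lower number from compound 2 to compound 4 (0.04 log units; within the scatter). Set beside the earlier step, the same change reads alike on both cores, with no measurable dependence on the core: the same change on two cores in this assay, a 1.3-fold higher number (0.12 log units; within the scatter) from compound 3 to compound 1 and a 1.1-fold lower number (0.04 log units; within the scatter) from compound 2 to compound 4, 1.5-fold (0.16 log units) apart, within the scatter of two such steps. Among the compounds shown here, this supports carrying the swap between these two cores as a change that leaves the number within the scatter, but it rests on only two pairs, cannot resolve any core dependence smaller than the scatter, and does not show that the result extends to other cores.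

The compounds shown leave open how an amine, a nitrile or a carboxylic acid in place of the halogen on this aromatic ring would read in this assay, since chloro and bromo are the only groups compared there. They also leave open whether the swap would stay as quiet on a core carrying something other than the two groups seen here, such as a morpholine.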